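Hydroxy to methoxy from compound 3 to compound 4

This account rests on a few compounds, and the source may have more. Where it says the series, first, only, none or still open, it means among the compounds named here.

In a functional assay on PC-3 cells (Homo sapiens) for inhibition, read by sulforhodamine B assay, with a stated time of 48 h (on this read-out higher numbers stand for weaker inhibition of growth and lower numbers for stronger inhibition of growth), compound 3 (`CC1(/C=C/c2ccc(O)cc2)C=CC(=O)O1`) reads 138000 nM and stands within the scatter of compound 1 (`CC1(/C=C/c2ccccc2)C=CC(=O)O1`) at 86900 nM on this read-out. Compound 2 (`COc1ccc(/C=C/C2(C)C=CC(=O)O2)c(OC)c1`) reads 63500 nM here, a lower number than compound 3 shows, and that gap lies beyond the scatter.

Compound 4 (`COc1ccc(/C=C/C2(C)C=CC(=O)O2)cc1`) changes one place in compound 3: methyl in place of hydrogen on an oxygen on an aromatic ring in words, methyl in place of hydrogen on an oxygen on an aromatic ring, which reads hydroxy to methoxy.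

Within the data shown here, the only measured step involving this hydroxy is a 1.6-fold higher number from compound 1 to compound 3 (0.20 log units; within the scatter) and it stays within the scatter. Among the measured compounds shown here, no measured pair shows the methoxy change alone. For the measured compounds named here, compound 2 at 63500 nM is the only measured compound with methoxy on the aromatic ring, but it differs from compound 4 by more than that single group, so it offers only indirect support.

A slightly lower number than for compound 3 is therefore expected, with no step beyond the scatter. The estimated step is a 1.6-fold lower number from compound 3 to compound 4 (0.21 log units; within the scatter) in this expectation. For compound 4 the expected value is 85000 nM with an estimated range from 50000 nM to 140000 nM as the working figure.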

Compound 4, concentration for total growth inhibition: 145000 nM
Beside the measured number, compound 4's estimate is 1.7-fold (0.23 log units) below it; the whole stated range lies below it.
By their numbers in this assay, from the lowest: compounds 2, 1, 3 and 4 (each within the scatter of the next, the first and the last beyond it).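

Working notes on the oxygen on the aromatic ring: in this assay, methyl in place of the hydrogen on that oxygen leaves the reading where the hydroxy compound stood (a 1.1-fold higher number from compound 3 to compound 4 (0.02 log units; within the scatter)), so this change gives no separation on this read-out. The unsubstituted compound is also not separated from the methoxy compound (a 1.7-fold higher number from compound 1 to compound 4 (0.22 log units; within the scatter)), which adds to the earlier hydroxy step (a 1.6-fold higher number from compound 1 to compound 3 (0.20 log units; within the scatter)): hydrogen, hydroxy and methoxy at this carbon all read within the scatter of one another, and the series stays weak throughout. The one step here that clears the scatter is the loss of the second methoxy (a 2.3-fold higher number from compound 2 to compound 4 (0.36 log units; beyond the scatter)), and it is modest, so among these compounds the second methoxy on the ring, not the cap on the oxygen, goes with a shift in the reading.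

As far as these compounds go, whether this flat response holds for an amine, a carboxylic acid or a longer alkoxy chain in the same place stays open, as does whether the second methoxy step would recur on the hydroxy compound. No measurement at hand accounts for the flat response or for that single larger step.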